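Removing a Methoxy Group: What to Expect for Compound 3

The source may report more compounds than this note shows. Statements on the series, on what has been measured and on what is new or still open speak of the compounds shown alone.

Of the compounds shown here, two have so far been measured in an assay on CHO cells for displacement of a labelled ligand from adenosine receptor A1 (Homo sapiens), read by scintillation counting, with a stated time of 120 min, tested at 1 uM; on this read-out lower numbers stand for less inhibition and higher numbers for more inhibition at the one concentration tested (going by the name of the read-out). Compound 1 `Cc1nc(NC(=O)NCc2ccccc2)c2nn(-c3ccccc3)cc2n1` gives 26% in this assay. Compound 2 `COc1ccc(-n2cc3nc(C)nc(NC(=O)c4ccco4)c3n2)cc1` gives 6% in this assay, which is the lower of the two numbers, and its gap to compound 1 lies beyond the usual scatter of such measurements.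

Compound 3 `Cc1nc(NC(=O)c2ccco2)c2nn(-c3ccccc3)cc2n1` has not yet been measured. It differs from compound 2 in one place: hydrogen in place of methoxy on an aromatic carbon. Everything else of compound 2 is kept in compound 3.

Among the compounds with values here, no measured pair shows this change on its own, so nothing in the data says how it acts here. Compound 2 already sits at the bottom of the two numbers, which leaves little room for a downward move. The step from compound 2 to compound 3 is therefore expected to be small, a number 6 percentage points higher from compound 2 to compound 3 (within the scatter), and not beyond the scatter, if anything slightly upward. Compound 3 is estimated at 12% in this assay, with a range from 0% to 30%, because compound 2 gives 6% and the change is modest.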

Compound 3, a percentage reported as inhibition, at one concentration (the size of the read-out at that concentration, not a potency): 20%
Compound 3: middle estimate off by 8 percentage points, on the low side; the measured number falls inside the stated range.
By their numbers in this assay, from the lowest: compound 2; then compounds 3 and 1 (each within the scatter of the next).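

In this assay, within the data shown here, hydrogen in place of methoxy on an aromatic carbon, para to a large group, gives a number 14 percentage points higher from compound 2 to compound 3 (beyond the scatter), so this is the first single-change evidence that the read-out responds to this position, with the 4-methoxyphenyl to phenyl change separating the two compounds. The second single change, furan-2-yl in place of benzylamino on a carbonyl carbon, gives a number 6 percentage points lower from compound 1 to compound 3 (within the scatter), which means that these two groups are not told apart in this assay when the phenyl is kept. No measurement available here explains either result.

The compounds shown leave open whether a hydroxyl group, an amine or a longer chain such as ethoxy at this ring position would read like hydrogen, like methoxy or like neither, and whether the methoxy step would carry over to a compound with benzylamino on the carbonyl carbon instead of furan-2-yl. Going by these compounds, these numbers also come from a single concentration, so they give no potency, and how the compounds would compare across a range of concentrations remains open.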